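Swapping the Aryl Group of Compound 3 for 2-Hydroxyphenyl

The source may hold more compounds than are shown below. What is called first, only, known or untested is meant among the compounds shown, and "the series" means these compounds.

Of the compounds shown here, three sharing one core have been measured in a functional assay, with a stated time of 30 min; on this read-out lower numbers stand for stronger inhibition and higher numbers for weaker inhibition. Compound 1 `CCCCc1oc2ccc(/N=C/c3ccc(OC)cc3OC)cc2c1C(=O)c1ccc(OC)cc1` gives 20.5 ug/mL. Compound 2 `CCCCc1oc2ccc(/N=C/c3ccc([N+](=O)[O-])cc3)cc2c1C(=O)c1ccc(OC)cc1` gives 53.1 ug/mL. Compound 3 `CCCCc1oc2ccc(/N=C/c3ccc(Cl)cc3Cl)cc2c1C(=O)c1ccc(OC)cc1` gives 2.44 ug/mL, the lowest of the three numbers, with compound 1 as its nearest neighbour and compound 2 as its furthest. The steps among them read a 2.6-fold higher number from compound 1 to compound 2 (0.41 log units; beyond the scatter), an 8.4-fold lower number from compound 1 to compound 3 (0.92 log units; beyond the scatter) and a 22-fold lower number from compound 2 to compound 3 (1.34 log units; beyond the scatter).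

Compound 4 `CCCCc1oc2ccc(/N=C/c3ccccc3O)cc2c1C(=O)c1ccc(OC)cc1` has not yet been measured. It differs from compound 3 in one place: 2-hydroxyphenyl in place of 2,4-dichlorophenyl on a carbon with a double bond to nitrogen. The two steps that arrive at compound 3, an 8.4-fold lower number from compound 1 to compound 3 (0.92 log units; beyond the scatter) and a 22-fold lower number from compound 2 to compound 3 (1.34 log units; beyond the scatter), both put the 2,4-dichlorophenyl in place of another aryl group on the carbon with a double bond to nitrogen, and both lower the number well beyond the scatter. The change to compound 4 removes that 2,4-dichlorophenyl again, so the number is expected to move back upward, by a modest amount, giving an expected step of a 6.1-fold higher number from compound 3 to compound 4 (0.79 log units; beyond the scatter). Nothing measured here tells how a 2-hydroxyphenyl at this place compares with the 2,4-dimethoxyphenyl or the 4-nitrophenyl, so the range is kept wide. Compound 4 is estimated at 15 ug/mL, within a range from 5 ug/mL to 45 ug/mL.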

Compound 4, half-maximal inhibitory concentration: 99.4 ug/mL
The estimate for compound 4 lay 6.6-fold (0.82 log units) below the measured number; measured number outside the range, above it.
By their numbers in this assay, from the lowest: compound 3; then compound 1; then compounds 2 and 4 (each within the scatter of the next).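

In this assay, the place on the carbon with a double bond to nitrogen proves more sensitive than the first three compounds showed: a 41-fold higher number from compound 3 to compound 4 (1.61 log units; beyond the scatter), the largest step among the four compounds, and it takes away the whole of the gain seen with the 2,4-dichlorophenyl. The 2-hydroxyphenyl does not return the number to the level of the 2,4-dimethoxyphenyl, as a 4.8-fold higher number from compound 1 to compound 4 (0.69 log units; beyond the scatter), while a 1.9-fold higher number from compound 2 to compound 4 (0.27 log units; within the scatter), so the 2-hydroxyphenyl and the 4-nitrophenyl cannot be told apart here. Compound 3, the only one of the four with chlorine, now stands clearly apart at the low end, beyond the scatter from each of the other three. Nothing shown accounts for the size of this rise.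

From the compounds shown here alone, whether the low number of compound 3 needs both chlorines remains open, and a phenyl group carrying a single chlorine would address that. A plain phenyl group and a phenyl group carrying a single methoxy would show whether the high number of compound 4 reflects its hydroxyl or merely the absence of chlorine.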